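The compounds below may be only part of what the source reports. "The series", "measured", "known", "first", "only" and "open" are said of these compounds alone.

Measured so far in a functional assay on MGC-803 cells (Homo sapiens) for inhibition, read by sulforhodamine B assay; a lower number here means a stronger inhibitor, a higher number a weaker inhibitor:
compound 1 `CCc1ccc(NC2=CC(=O)c3c(nc4n3[C@H]3OC[C@@H](O)[C@H]3OC4)C2=O)cc1` gives 1110 nM
compound 2 `Cc1ccc(NC2=CC(=O)c3c(nc4n3[C@H]3OC[C@@H](O)[C@H]3OC4)C2=O)cc1C` gives 1050 nM
compound 3 `O=C1C=C(NC2CCCCC2)C(=O)c2c1nc1n2[C@H]2OC[C@@H](O)[C@H]2OC1` gives > 8000 nM

For compound 3 the value is a limit of the assay, not a number, so compound 3 is known only as a weak inhibitor there; this is the limit of > 8000 nM in this assay, at which 1 of the 3 values shown sits. Compounds 1 and 2 both carry an aromatic ring on the amine nitrogen, and the step of a 1.1-fold lower number from compound 1 to compound 2 (0.02 log units; within the scatter) shows that exchanging one set of small substituents on that ring for another left the result within the scatter. Compound 4 `O=C1C=C(Nc2ccccc2)C(=O)c2c1nc1n2[C@H]2OC[C@@H](O)[C@H]2OC1` is the unmeasured partner of compound 3. The change is phenyl in place of cyclohexyl on an amine nitrogen. Within the data shown here, no measured step covers this exact change; the only step known, from compound 1 to compound 2, concerns substituents on a ring that is already aromatic. What the data do show is that the two compounds with an aromatic ring on that nitrogen give numbers, while the one with the saturated ring gives a limit. Compound 4 is therefore expected to move toward compound 1 and compound 2, with an expected step of an at least 4.4-fold lower number from compound 3 to compound 4 (0.64 log units; beyond the scatter) toward a lower number. The size of that step is uncertain: compound 3 offers only a limit as a starting point. The estimate for compound 4 in this assay is 1800 nM, expected to fall between 700 nM and 5000 nM.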

Compound 4, half-maximal inhibitory concentration: 1730 nM
Compound 4: the middle estimate sits 1.0-fold (0.02 log units) above what was measured, and the stated range covers the measured number.
By their numbers in this assay, from the lowest: compounds 2, 1 and 4 (each within the scatter of the next). At a limit, above all of these: compound 3.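

Exchanging cyclohexyl for phenyl on the amine nitrogen, with the shared core unchanged, gives in this assay an at least 4.6-fold lower number from compound 3 to compound 4 (0.66 log units; beyond the scatter). Among these compounds, this is the first direct comparison of the two ring types at this position: the groups have the same heavy-atom count and differ in whether the six-membered ring is aromatic or non-aromatic, so the choice of ring matters here. Compound 4, with a plain phenyl ring, gives 1730 nM and compound 1, with 4-ethylphenyl, gives 1110 nM; these values lie within the scatter of each other, so among these compounds a substituent on the aromatic ring is not needed to reach this range. The full size of the step stays unknown because compound 3 is known only through a limit of the assay: the limit of > 8000 nM in this assay, at which 1 of the 4 values shown sits.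

Still open, going by these compounds, is whether an aromatic ring that contains nitrogen, such as pyridyl, or a benzyl group on the same nitrogen would behave like phenyl. Also open, on these data alone, is whether a methoxy group or a chlorine atom on the phenyl ring would move the number beyond the scatter.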